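Methyl for Trifluoromethoxy on the Aryl Piperazine

The source may report more compounds than this note shows. Statements on the series, on what has been measured and on what is new or still open speak of the compounds shown alone.

Compound 2 `CN(C)C(=O)c1cccnc1NCCCN1CCN(c2ccccc2OC(F)(F)F)CC1` gives 100 nM in a functional assay on aorta for antagonist activity at Alpha-1D adrenergic receptor (Rattus norvegicus) (a lower number here means tighter binding, a higher number weaker binding), the higher of the two numbers recorded. Compound 1 `COc1ccccc1N1CCN(CCCSc2ccccc2C(=O)N(C)C)CC1` gives 12.6 nM in this assay, and the gap between the two values lies beyond the scatter. Compound 3 `Cc1ccccc1N1CCN(CCCNc2ncccc2C(=O)N(C)C)CC1` differs from compound 2 in one place: methyl in place of trifluoromethoxy on an aromatic carbon. Among the measured compounds shown here, no comparable step among measured compounds exists, so the direction rests on little; the step is expected to be a 1.7-fold lower number from compound 2 to compound 3 (0.22 log units; within the scatter), a modest move toward a lower number that may still fall within the scatter. Compound 3 is therefore estimated at 60 nM, with a range from 20 nM to 200 nM.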

Compound 3, dissociation constant: 10 nM
Estimate against measurement, compound 3: 6.0-fold (0.78 log units) above; the measured number lies below the stated range.
By their numbers in this assay, from the lowest: compounds 3 and 1 (each within the scatter of the next); then compound 2.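

Among the compounds shown here, the aromatic carbon ortho to a large group is not indifferent to what it carries: in this assay, methyl in place of trifluoromethoxy gives a 10-fold lower number from compound 2 to compound 3 (1.00 log units; beyond the scatter), a first single-place step on this series and one beyond the scatter. The loss of four heavy atoms accompanies this change, but nothing measured here explains the step.

The compounds shown leave open how chlorine, ethyl or a nitrile would read at this place. They also leave open whether the same change would give a similar step on the core of compound 1.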